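Swapping the Aromatic Amide Group in an Enzyme Inhibitor Series

The source may report more compounds than this note shows. Statements on the series, on what has been measured and on what is new or still open speak of the compounds shown alone.

Compound 1 `O=C(NCc1ccc(S(=O)(=O)c2ccccc2)cc1)c1nc2ccncc2s1`: 210 nM
Compound 2 `O=C(NCc1ccc(S(=O)(=O)N2CCCCC2)cc1)c1cc2cnccc2s1`: 150 nM
Compound 3 `O=C(NCc1ccc(S(=O)(=O)c2ccccc2)cc1)c1cc(-c2cccnc2)no1`: 41 nM

Of the compounds shown here, three have been measured in an assay for inhibition of Nicotinamide phosphoribosyltransferase (Homo sapiens), read by mass spectrometry, with stated times of 15 min and 30 min; a lower number here means a stronger inhibitor, a higher number a weaker inhibitor. Compound 2 gives 150 nM, the second highest of the three numbers. Compound 1 gives 210 nM, which lies within the scatter of compound 2. Compound 3 gives 41 nM, a lower number that lies beyond the scatter relative to compound 2.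

Compound 4, `O=C(NCc1ccc(S(=O)(=O)N2CCCCC2)cc1)c1cnc2nccn2c1`, has not yet been measured. It differs from compound 2 by a group of 9 heavy atoms (6 carbon, 3 nitrogen; one five-membered aromatic ring with 2 hetero atoms, one six-membered aromatic ring with 2 hetero atoms) in place of a group of 9 heavy atoms (7 carbon, 1 nitrogen, 1 sulfur; one five-membered aromatic ring with 1 hetero atom, one six-membered aromatic ring with 1 hetero atom), on a carbonyl carbon. Both groups are a fused pair of aromatic rings, but the entering one replaces sulfur with nitrogen and carries more ring hetero atoms. Within the data shown here, none of the measured pairs shows a step at this position, so the size of the effect is open. A modest weakening is expected, the estimated step from compound 2 to compound 4 being a 2.0-fold higher number from compound 2 to compound 4 (0.30 log units; within the scatter), though a result within the scatter would not surprise. For compound 4 the expected value in this assay is 300 nM, with a range from 80 nM to 1200 nM.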

Compound 4, half-maximal inhibitory concentration: 3 nM
The estimate for compound 4 lay 100-fold (2.00 log units) above the measured number; measured number outside the range, below it.
By their numbers in this assay, from the lowest: compound 4; then compound 3; then compounds 2 and 1 (each within the scatter of the next).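

The group on the carbonyl carbon turns out to matter greatly: exchanging one fused pair of aromatic rings for another with the same heavy-atom count gives a 50-fold lower number from compound 2 to compound 4 (1.70 log units; beyond the scatter) in this assay. Heavy-atom count alone therefore does not set the number here, since the step goes with a change in ring make-up: nitrogen enters, sulfur leaves, and the entering group carries more ring hetero atoms. Nothing available explains why the step is so large.

Which of the ring nitrogens in compound 4 goes with the step remains open, as only this one arrangement is shown. From the compounds shown here alone, it is also open whether adding an amine or a carboxylic acid to these fused rings would keep the low number.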